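The source may report more compounds than this note shows. Statements on the series, on what has been measured and on what is new or still open speak of the compounds shown alone.

Compound 2, `CCN1C/C(=C\c2ccc(OC)c(OC)c2)C(=O)/C(=C/c2ccc(OC)c(OC)c2)C1`, and compound 1, `COc1ccc(/C=C2\CN(C)C/C(=C\c3ccc(OC)c(OC)c3)C2=O)cc1OC`, share a core and differ only in the group on the ring nitrogen. In a functional assay on NCI-H1975 cells (Homo sapiens) for cytotoxicity, read by MTT assay, with a stated time of 72 h (a higher number here means a weaker inhibitor, a lower number a stronger inhibitor), compound 2 gives 8500 nM, and compound 1 gives 6600 nM, a step of a 1.3-fold lower number from compound 2 to compound 1 (0.11 log units; within the scatter) for the change (hydrogen in place of methyl on a saturated chain carbon bound to an amine nitrogen in a ring). Compound 3, `COc1cc(/C=C2\CN(C(=O)C(C)C)C/C(=C\c3cc(OC)c(OC)c(OC)c3)C2=O)cc(OC)c1OC`, has a different core, and the difference between the two cores is not broken down here; in this assay compound 3 gives 1900 nM, the lowest number of the three and beyond the scatter from both others. Compound 4, `CCC(=O)N1C/C(=C\c2cc(OC)c(OC)c(OC)c2)C(=O)/C(=C/c2cc(OC)c(OC)c(OC)c2)C1`, is not yet measured; it differs from compound 3 by hydrogen in place of methyl on a saturated chain carbon bound to a carbonyl carbon and a saturated chain carbon, the same kind of change as from compound 2 to compound 1, though here the carbon is bound to a carbonyl carbon and a saturated chain carbon rather than to an amine nitrogen in a ring. Because the earlier step of a 1.3-fold lower number from compound 2 to compound 1 (0.11 log units; within the scatter) stayed within the scatter, the step from compound 3 to compound 4 is expected to be about a 1.1-fold lower number from compound 3 to compound 4 (0.02 log units; within the scatter). Compound 4 is therefore estimated at 1800 nM, between 900 nM and 3800 nM.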

Compound 4, half-maximal inhibitory concentration: 1700 nM
The estimate for compound 4 lay 1.1-fold (0.02 log units) above the measured number; measured number inside the range.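

In this assay the change from isopropylcarbonyl to propanoyl gives a 1.1-fold lower number from compound 3 to compound 4 (0.05 log units; within the scatter), and this step stands close to the earlier one: the same change on two cores in this assay, a 1.3-fold lower number (0.11 log units; within the scatter) from compound 2 to compound 1 and a 1.1-fold lower number (0.05 log units; within the scatter) from compound 3 to compound 4, 1.2-fold (0.06 log units) apart, within the scatter of two such steps In these two pairs, then, hydrogen in place of methyl carries from one core to the other as a step that cannot be told from the scatter. Two pairs do not show that this would hold on further cores, and the carbon concerned is not the same: in one pair it is bound to an amine nitrogen in a ring, in the other to a carbonyl carbon and a saturated chain carbon.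

The compounds shown leave open whether a longer chain, an amine or a carboxylic acid in place of the propanoyl group would give a step beyond the scatter.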